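Removing the sulfamoyl group from an aryl dimethyltriazene

This account rests on a few compounds, and the source may have more. Where it says the series, first, only, none or still open, it means among the compounds named here.

Measured compounds:
compound 1, `CN(C)/N=N/c1ccc(S(N)(=O)=O)cc1C(N)=O`, 3.32
compound 2, `CN(C)/N=N/c1ccc(S(=O)(=O)Nc2ncccn2)cc1`, 3.74

Compound 1 is one of two aryl dimethyltriazenes tested in a functional assay on L1210 cells (Mus musculus) for antiproliferative activity; a higher number here means a more potent compound, by a factor of ten per unit of this negative logarithm, a lower number a less potent compound. In this assay compound 1 gives 3.32, the lowest of the two numbers; compound 2 gives 3.74, which lies above compound 1 beyond the usual scatter. Compound 3, `CN(C)/N=N/c1ccccc1C(N)=O`, has not yet been measured. It differs from compound 1 in one place: hydrogen in place of sulfamoyl on an aromatic carbon. Among the compounds with values here, no step between two measured compounds isolates this change, so there is nothing to guide its size or direction. On the two values available, compound 3 is expected to stay close to compound 1, with a step of a number 0.02 log units lower from compound 1 to compound 3 (within the scatter) that is not expected to exceed the scatter in either direction. For compound 3 the expected value in this assay is 3.3, with a range from 2.7 to 3.9.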

Compound 3, logarithm of the reciprocal of the active concentration, log(1/C): 3.31
The estimate for compound 3 lay 0.01 log units below the measured number, and the stated range covers the measured number.
By their numbers in this assay, from the lowest: compounds 3 and 1 (each within the scatter of the next); then compound 2.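

In this assay, hydrogen in place of sulfamoyl on the aromatic carbon meta to the carbamoyl group gives a number 0.01 log units lower from compound 1 to compound 3 (within the scatter), so compound 1 and compound 3 cannot be told apart. Within the data shown here, this is the first measured step at this position, and it shows that, with the carbamoyl group present, sulfamoyl and its 4 heavy atoms can leave this carbon while the antiproliferative read-out stays within the scatter. No other measurement bears on this result.

The compounds shown leave open whether another group on this carbon, such as an amine, a carboxylic acid or a methyl group, would also stay within the scatter. They also leave open whether the same replacement would give a step of similar size on a core lacking the carbamoyl group.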